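From Fluoro to Chloro: Expecting a Small Step

This account rests on a few compounds, and the source may have more. Where it says the series, first, only, none or still open, it means among the compounds named here.

Of the compounds shown here, three sharing one core have been measured in an ADME assay on 184B5 cells (Homo sapiens) for cytotoxicity, read by MTT assay, with a stated time of 72 h; on this read-out higher numbers stand for weaker inhibition of growth and lower numbers for stronger inhibition of growth. Compound 1 `N#C[Se]c1ccc(NC(=O)OCc2ccc([N+](=O)[O-])cc2)cc1` gives 6000 nM. Compound 3 `N#C[Se]c1ccc(NC(=O)OCC2=Cc3ccccc3S2(=O)=O)cc1` gives 5300 nM in this assay. Compound 2 `N#C[Se]c1ccc(NC(=O)Oc2ccc(F)cc2)cc1`, which carries a fluoro group, gives 6900 nM in this assay. Its number is the highest of the three figures, yet its gaps to compound 1 and to compound 3 both fall within the usual scatter of repeated measurements, so the three compounds cannot be told apart on these numbers.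

Compound 4 `N#C[Se]c1ccc(NC(=O)Oc2ccc(Cl)cc2)cc1` has not yet been measured. It differs from compound 2 in one place: chloro in place of fluoro on an aromatic carbon. Among the compounds with values here, no step between two measured compounds isolates a change of this kind, so there is no measured guide to its size. Replacing one halogen by another on the same aromatic carbon is a small alteration, and the expectation is that compound 4 stays close to compound 2. The expected step of a 1.1-fold lower number from compound 2 to compound 4 (0.03 log units; within the scatter) is therefore small, without a preferred direction, and unlikely to reach beyond the scatter. In this assay compound 4 is estimated to give 6500 nM, with a range from 3000 nM to 14000 nM.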

Compound 4, concentration for 50% growth inhibition: 5600 nM
Estimate against measurement, compound 4: 1.2-fold (0.06 log units) above, and the stated range covers the measured number.
By their numbers in this assay, from the lowest: compounds 3, 4, 1 and 2 (each within the scatter of the next).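

Within the data shown here, until now no two measured compounds differed in one place, so nothing showed how much this position could matter. In this assay, chloro in place of fluoro on an aromatic carbon, para to a large group, now gives the first such comparison, a 1.2-fold lower number from compound 2 to compound 4 (0.09 log units; within the scatter). This means that, for this one pair, exchanging one halogen for the other does not move the read-out beyond what repeated measurements of the same compound would be expected to show, so compound 2 and compound 4 cannot be told apart here, and no measurement shown here bears on the reason for this result.

As far as these compounds go, both groups compared at this position are halogens, so it remains open whether something of a different kind on the same aromatic carbon, such as an amine, a carboxylic acid or a longer chain, would produce a step beyond the scatter. A single pair also leaves open whether the same exchange would give a similarly small step on a different core or at a different place on the ring.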